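The compounds below may be only part of what the source reports. "The series", "measured", "known", "first", "only" and "open" are said of these compounds alone.

Compound 2 `CCc1cc2ccccc2nc1-c1cn(-c2ccc(F)cc2)nn1` was tested in a functional assay on THP-1 cells (Homo sapiens) for cytotoxicity, read by MTT assay, with a stated time of 24 h; a higher number here means a weaker inhibitor, a lower number a stronger inhibitor. In this assay compound 2 gives > 100 ug/mL, which is a limit of the assay rather than a number. Compound 1 `CCCCCc1cc2ccccc2nc1-c1cn(-c2ccc(F)cc2)nn1` carries a longer chain. In this assay compound 1 gives > 100 ug/mL, also a limit. Going by the values given here, the only step available, a step that the two limits leave unreadable from compound 1 to compound 2, cannot be sized because both values sit at the limit of > 100 ug/mL in this assay, at which 2 of the 2 values shown sit. Compound 3 `CCCc1cc2ccccc2nc1-c1cn(-c2ccc(F)cc2)nn1` differs from compound 2 by methyl in place of hydrogen on a saturated chain carbon, two bonds along the chain from an aromatic carbon. No readable step bears on this change, so compound 3 is expected to remain at the same limit, with a step that the limit leaves unreadable from compound 2 to compound 3. The estimate for compound 3 is 150 ug/mL, ranging from 60 ug/mL to 400 ug/mL.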

Compound 3, half-maximal inhibitory concentration: > 100 ug/mL
Compound 3 was reported as a limit; the forecaster's own chance of this, stated with the estimate: 85%; the middle value does not contradict the limit.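

No size can be read for any step among compound 1, compound 2 and compound 3, because each result is only a limit: the limit of > 100 ug/mL in this assay, at which 3 of the 3 values shown sit.

These compounds leave open whether the length of the chain changes cytotoxicity at all in this assay.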